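The source may report more compounds than this note shows. Statements on the series, on what has been measured and on what is new or still open speak of the compounds shown alone.

In a functional assay on K562 cells (Homo sapiens), read by MTT assay, with a stated time of 72 h (on this read-out lower numbers stand for stronger inhibition and higher numbers for weaker inhibition), compound 1 `Nc1nc(N)c2c(-c3ccco3)cn([C@@H]3O[C@H](CO)[C@@H](O)[C@H]3O)c2n1` gives > 20000 nM, which is a limit and not a number. As far as these compounds go, compound 2 `COc1nc(N)nc2c1c(-c1ccco1)cn2[C@@H]1O[C@H](CO)[C@@H](O)[C@H]1O` gives > 20000 nM, which is also a limit and not a number, so its true position on the scale stays unknown. Compound 3 `COc1nc(N)nc2c1c(-c1ccccc1)cn2[C@@H]1O[C@H](CO)[C@@H](O)[C@H]1O` carries phenyl in place of furan-2-yl on an aromatic carbon. Going by the values given here, the only measured step is methoxy in place of amino on an aromatic carbon, elsewhere on the shared core, and it is a step that the two limits leave unreadable from compound 1 to compound 2. It therefore offers no size to carry over. All the evidence so far is the limit of > 20000 nM in this assay, at which 2 of the 2 values shown sit. No large step is expected in this assay because compound 2 sits at > 20000 nM and no measured change has left that limit. The estimated step is a number no higher from compound 2 to compound 3 (the limit leaves the size open). For compound 3 the expected value is 20000 nM, within an estimated range of 8000 nM to 40000 nM, and most likely only a limit will be reported.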

Compound 3, half-maximal inhibitory concentration: > 20000 nM
Compound 3 was reported as a limit; the forecaster's own chance of this, stated with the estimate: 85%; the middle value lies on the limit itself.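

In this assay, going by these compounds alone, compound 3 gives > 20000 nM as a limit and not a number, and compound 2 also stands only at a limit, so no step between them can be read. The true strength of each compound stays open, as does whether either change matters, and the evidence so far is only this: the limit of > 20000 nM in this assay, at which 3 of the 3 values shown sit.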